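The source may hold more compounds than are shown below. What is called first, only, known or untested is meant among the compounds shown, and "the series" means these compounds.

Measured in a functional assay on HeLa cells (Homo sapiens) for inhibition, read by cell counting, with a stated time of 96 h; on this read-out higher numbers stand for weaker inhibition and lower numbers for stronger inhibition:
- compound 1 `CCN(CC)CN1C(=O)/C(=N/NC(=S)Nc2ccc(Cl)cc2)c2ccccc21`: 7600 nM
- compound 2 `CCN(CC)CN1C(=O)/C(=N/NC(=S)Nc2ccc(OC)cc2)c2ccccc21`: 4400 nM

Not yet measured: compound 3 `CCN(CC)CN1C(=O)/C(=N/NC(=S)Nc2ccccc2)c2ccccc21`.

Within the data shown here, only one step has been measured so far: a 1.7-fold lower number from compound 1 to compound 2 (0.24 log units; within the scatter). Among the measured compounds shown here, compound 2, at 4400 nM, cannot be separated from the only other measured compound on these numbers.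

The next step removes the substituent from compound 2 to give compound 3: hydrogen in place of methoxy on an aromatic carbon. In words, this is hydrogen in place of methoxy on an aromatic carbon, turning 4-methoxyphenyl into phenyl.

For the measured compounds named here, the single measured step bears on this change, as it is also an exchange on an aromatic carbon of the same ring, and it stayed within the scatter. Going by the values given here, there is no measured example with hydrogen at this place, so this support is thin. In this assay, no change beyond the scatter is expected, and no direction can be called with confidence.

The expected step is a 1.3-fold higher number from compound 2 to compound 3 (0.10 log units; within the scatter). For compound 3 the estimated value is 5500 nM, with an expected range of 2500 nM to 12000 nM.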

Compound 3, half-maximal inhibitory concentration: 8300 nM
Compound 3: the middle estimate sits 1.5-fold (0.18 log units) below what was measured; the measured number falls inside the stated range.
By their numbers in this assay, from the lowest: compounds 2, 1 and 3 (each within the scatter of the next).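

In this assay, the unsubstituted phenyl gives this series a reading with hydrogen on this aromatic carbon, and both steps to it stay within the scatter: a 1.9-fold higher number from compound 2 to compound 3 (0.28 log units; within the scatter), and a 1.1-fold higher number from compound 1 to compound 3 (0.04 log units; within the scatter). Methoxy and chloro therefore cannot be separated from hydrogen at this place, so neither group shown has a measurable effect on the number in this small set, and the earlier pair could not show this without a hydrogen reference. No supporting measurement is available to explain this result.

As far as these compounds go, whether any group on this carbon can move the number beyond the scatter stays open, since the three compounds cover only methoxy, chloro and hydrogen; a carboxylic acid, an amine or a longer chain such as butoxy would test this more widely. From the compounds shown here alone, the diethylamino group and the rest of the shared core are the same in all three compounds, so what changes there would do also stays open.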